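A few compounds are considered here, and "the series" means these few. Any claim that something is new, unique, unknown or untested is made for them only; others in the source may bear on it.

Measured so far in a functional assay on MCF7 cells (Homo sapiens) for cytotoxicity, read by MTT assay, with a stated time of 72 h; on this read-out lower numbers stand for higher toxicity in this test and higher numbers for lower toxicity in this test:
compound 1, `O=C(/N=C(/NC(=O)c1cc(-c2ccccc2)nc2ccccc12)[Se]Cc1ccccc1)c1cc(-c2ccccc2)nc2ccccc12` — 97000 nM
compound 2, `CS/C(=N\C(=O)c1cc(-c2ccccc2)nc2ccccc12)NC(=O)c1cc(-c2ccccc2)nc2ccccc12` — > 100000 nM

In this assay compound 1 gives 97000 nM. For compound 2 the read-out is a limit, not a number: > 100000 nM, the point described by the limit of > 100000 nM in this assay, at which 1 of the 2 values shown sits. The step of an at least 1.0-fold higher number from compound 1 to compound 2 (0.01 log units; that floor lies within the scatter) lies within the scatter, so the two values show no separation beyond it; compound 2 stands at the ceiling of what this assay reports, with compound 1 just short of it.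

Compound 3, `C[Se]/C(=N\C(=O)c1cc(-c2ccccc2)nc2ccccc12)NC(=O)c1cc(-c2ccccc2)nc2ccccc12`, differs from compound 2 by a group of 2 heavy atoms (1 carbon, 1 selenium; no ring) in place of a group of 2 heavy atoms (1 carbon, 1 sulfur; no ring), on a carbon with a double bond to nitrogen. For the measured compounds named here, the one measured step bears only loosely on this: from compound 1 to compound 2 both the selenium-bearing group and its attached ring were exchanged at once, and that step came out as an at least 1.0-fold higher number from compound 1 to compound 2 (0.01 log units; that floor lies within the scatter), within scatter. Going by the values given here, no measured pair isolates selenium against sulfur alone. With no step beyond scatter anywhere in the set, the expected step is a number no higher from compound 2 to compound 3 (the limit leaves the size open), that is, none beyond scatter. Compound 3 is accordingly expected to land at 100000 nM, estimated between 45000 nM and 220000 nM, with a real chance that this assay again returns only a limit.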

Compound 3, concentration lethal to 50% of the cells: > 100000 nM
Compound 3 ended at the assay's limit; the forecaster's own chance of this, stated with the estimate: 55%; the middle value sits exactly at the limit.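

In this assay compound 3 returns only a limit, so selenium in place of sulfur on a carbon with a double bond to nitrogen brings no readable value with the methyl-bearing group, and the step between compound 2 and compound 3 cannot be read. For the compounds shown here, the one readable step is an at least 1.0-fold higher number from compound 1 to compound 3 (0.01 log units; that floor lies within the scatter), so hydrogen in place of phenyl on the saturated chain carbon bound to selenium shows no separation beyond the scatter. The series now gathers at the end of the read-out: the limit of > 100000 nM in this assay, at which 2 of the 3 values shown sit.

Whether selenium and sulfur differ at all on this carbon remains unresolved, as neither compound 2 nor compound 3 gives a number. Also open, from the compounds shown here alone, is whether a longer chain on the selenium, or an amine in place of the selenium-bearing group, would give a value clear of the limit.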